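Hydroxy to methoxy on the aryl of compound 3

A few compounds are considered here, and "the series" means these few. Any claim that something is new, unique, unknown or untested is made for them only; others in the source may bear on it.

Measured compounds:
- compound 1, `Nc1nc(Cc2ccccc2)nc2cn(-c3ccccc3O)nc12`: 19%
- compound 2, `COc1ccccc1-n1cc2nc(CCCc3ccccc3)nc(N)c2n1`: 6%
- compound 3, `Nc1nc(-c2ccco2)nc2cn(-c3ccccc3O)nc12`: 36%

In an assay on CHO cells for displacement of a labelled ligand from adenosine receptor A3 (Homo sapiens), read by scintillation counting, with a stated time of 60 min, tested at 1 uM (a lower number here means less inhibition, a higher number more inhibition at the concentration tested (going by the name of the read-out)), compound 3 gives the highest of the three numbers; compound 1 lies a number 17 percentage points higher from compound 1 to compound 3 (beyond the scatter) below it after exchange of furan-2-yl in place of benzyl on an aromatic carbon, and compound 2 lies lowest of all. Compound 4, `COc1ccccc1-n1cc2nc(-c3ccco3)nc(N)c2n1`, is not yet measured. It differs from compound 3 by methyl in place of hydrogen on an oxygen on an aromatic ring. Within the data shown here, no measured pair isolates this change: compound 2 carries the methoxy group but also a different chain on the core, so its value and that of compound 1 cannot be read as a single step. Among the measured compounds shown here, the only single-point step in this assay concerns the group on the aromatic carbon, not the oxygen. Without a directly comparable pair, a moderate fall is expected for compound 4 in this assay, of about a number 14 percentage points lower from compound 3 to compound 4 (beyond the scatter), with the furan-2-yl group retained. Compound 4 is therefore estimated at 22%, within 5% to 42%.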

Compound 4, a percentage reported as inhibition, at one concentration (the size of the read-out at that concentration, not a potency): 37%
Beside the measured number, compound 4's estimate is 15 percentage points below it; the measured number falls inside the stated range.
By their numbers in this assay, from the lowest: compound 2; then compound 1; then compounds 3 and 4 (each within the scatter of the next).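

In this assay, methyl in place of hydrogen on this oxygen, with furan-2-yl retained, gives a number 1 percentage points higher from compound 3 to compound 4 (within the scatter), so in this pair the hydroxy hydrogen is not needed for the inhibition read at the tested concentration. With methoxy held constant, the group on the aromatic carbon gives a number 31 percentage points higher from compound 2 to compound 4 (beyond the scatter), which agrees in direction with the hydroxy pair, a number 17 percentage points higher from compound 1 to compound 3 (beyond the scatter), and no listed pair goes against furan-2-yl. No measurement available here bears on either result, and neither can be tied to a cause.

On these data alone, whether hydroxy and methoxy also match with benzyl or 3-phenylpropyl in place of furan-2-yl remains open, as does the outcome for an ethoxy group or an amine on the aryl. These single-concentration percentages in this assay also leave the potency of compound 3 and compound 4 undefined.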